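Hydroxy in place of methoxy on an inactive growth inhibitor

The source may hold more compounds than are shown below. What is called first, only, known or untested is meant among the compounds shown, and "the series" means these compounds.

Compound 1 `O=C(Nc1cccc(-n2cc(-c3ccncc3)c(-c3ccc(Cl)c(O)c3)n2)c1)Nc1cccc(C(F)(F)F)c1` and compound 2 `COc1cc(-c2nn(-c3cccc(NC(=O)Nc4ccc(Cl)c(Cl)c4)c3)cc2-c2ccncc2)ccc1Cl` share a core and were both tested in a functional assay on HCT-15 cells (Homo sapiens) for inhibition, read by sulforhodamine B assay, with a stated time of 48 h; on this read-out lower numbers stand for stronger inhibition of growth and higher numbers for weaker inhibition of growth. For compound 1 the result is a limit of the assay, > 32500 nM. For compound 2 the result is likewise a limit, > 50000 nM. Both values are limits, as the two lines the limit of > 32500 nM in this assay, at which 1 of the 2 values shown sits, and the limit of > 50000 nM in this assay, at which 1 of the 2 values shown sits, show, so neither compound gave a measurable number and compound 2 stands at the limit with no measured value.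

Compound 3 `O=C(Nc1cccc(-n2cc(-c3ccncc3)c(-c3ccc(Cl)c(O)c3)n2)c1)Nc1ccc(Cl)c(Cl)c1` has not yet been tested in this assay. It differs from compound 2 by hydrogen in place of methyl on an oxygen on an aromatic ring, that is, methoxy to hydroxy on the 4-chloro-3-methoxyphenyl, giving 4-chloro-3-hydroxyphenyl. Within the data shown here, no measured step joins two compounds here, so no size of step is known. The step from compound 2 to compound 3 is expected to be a step that the limit leaves unreadable from compound 2 to compound 3, none beyond the scatter. Compound 3 is estimated at 60000 nM, in the range 20000 nM to 200000 nM, most likely again a limit.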

Compound 3, concentration for total growth inhibition: 29600 nM
Compound 3: the middle estimate sits 2.0-fold (0.31 log units) above what was measured, and the stated range covers the measured number.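

In this assay, turning the 4-chloro-3-methoxyphenyl into 4-chloro-3-hydroxyphenyl gives an at least 1.6-fold lower number from compound 2 to compound 3 (0.22 log units; that floor lies within the scatter). Placing 3,4-dichlorophenyl instead of 3-(trifluoromethyl)phenyl on the amide-type nitrogen gives an at least 1.0-fold lower number from compound 1 to compound 3 (0.04 log units; that floor lies within the scatter). Compound 3 is thus the only one of the three with a measured number rather than a limit, but the methoxy to hydroxy change can be sized only as a floor, because compound 2 stands at a limit: the limit of > 50000 nM in this assay, at which 1 of the 3 values shown sits.

Going by these compounds, how large either change really is stays open, so hydroxy cannot yet be said to matter for growth inhibition. Also open, on these data alone, is whether an amine or a longer chain such as ethoxy at this position would give a number clearly apart from that of compound 3.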